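A few compounds are considered here, and "the series" means these few. Any claim that something is new, unique, unknown or untested is made for them only; others in the source may bear on it.

Compound 1 `COc1cccc(NC(=O)c2cc(Cl)ccc2O)c1` was examined in a physicochemical assay for solubility (a higher number here means a more soluble compound, a lower number a less soluble compound), where compound 1 gives 2.3 ug/mL. Compound 2 `COc1ccc(Cl)c(NC(=O)c2cc(Cl)ccc2O)c1` differs from it by chloro in place of hydrogen on an aromatic carbon. In this assay compound 2 reports only a limit, < 1 ug/mL. The change brought an at least 2.3-fold lower number from compound 1 to compound 2 (0.36 log units; beyond the scatter), and the true size cannot be told because of the limit of < 1 ug/mL in this assay, at which 2 of the 3 values shown sit. Compound 3 `O=C(Nc1ccc(C(F)(F)F)cc1)c1cc(Br)ccc1O` rests on a different core; how the two cores differ is not broken down here. In this assay compound 3 likewise reports only a limit, < 1 ug/mL. Compound 4 `O=C(Nc1ccc(C(F)(F)F)cc1Cl)c1cc(Br)ccc1O` differs from compound 3 by chloro in place of hydrogen on an aromatic carbon, the same kind of change as that made to compound 1, though here the place is meta to a trifluoromethyl group rather than para to a methoxy group. Compound 4 is expected to give 0.4 ug/mL in this assay, a step that the limit leaves unreadable from compound 3 to compound 4, since the earlier chloro step lowered the number and compound 3 already sits at the limit of < 1 ug/mL in this assay, at which 2 of the 3 values shown sit. For compound 4 the expected span runs from 0.1 ug/mL to 1.5 ug/mL, most likely again only a limit.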

Compound 4, solubility: < 1 ug/mL
Compound 4 ended at the assay's limit; the forecaster's own chance of this, stated with the estimate: 85%; the middle value lies beyond the limit too.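

No step can be read from compound 3 to compound 4 in this assay, since both compounds report only a limit: the limit of < 1 ug/mL in this assay, at which 3 of the 4 values shown sit. On these data alone, whether chloro in place of hydrogen changes solubility on the core of compound 3 stays open.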